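Ester series: tert-butyl to benzyl on the shared core

The source may hold more compounds than are shown below. What is called first, only, known or untested is meant among the compounds shown, and "the series" means these compounds.

In a functional assay on MCF7 cells (Homo sapiens) for inhibition, read by MTT assay, with a stated time of 72 h (on this read-out higher numbers stand for weaker inhibition of growth and lower numbers for stronger inhibition of growth), compound 1 (`COC(=O)/C=C/C1=CC[C@H]2C(C)(C)CCC[C@]2(C)[C@H]1C=O`) gives 7000 nM, compound 2 (`CCOC(=O)/C=C/C1=CC[C@H]2C(C)(C)CCC[C@]2(C)[C@H]1C=O`) gives 30000 nM and compound 3 (`CC(C)(C)OC(=O)/C=C/C1=CC[C@H]2C(C)(C)CCC[C@]2(C)[C@H]1C=O`) gives 32000 nM. Compound 3 stands at the high-number end of the set, a place it shares with compound 2. The gap at that end is small: a 1.1-fold higher number from compound 2 to compound 3 (0.03 log units; within the scatter). The wider gap runs a 4.6-fold higher number from compound 1 to compound 3 (0.66 log units; beyond the scatter).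

Compound 4 (`CC1(C)CCC[C@]2(C)[C@@H](C=O)C(/C=C/C(=O)OCc3ccccc3)=CC[C@@H]12`) carries benzyl in place of tert-butyl on an oxygen next to a carbonyl group.

Two kinds of measured step bear on this change. Leaving the methyl ester cost a modest amount, a 4.3-fold higher number from compound 1 to compound 2 (0.63 log units; beyond the scatter), while the further change on the same oxygen gave a 1.1-fold higher number from compound 2 to compound 3 (0.03 log units; within the scatter). Within the data shown here, no measured compound carries an aromatic ring, so the data offer no direct precedent for benzyl. The expected step is therefore none beyond the scatter, with a slight lean to stronger inhibition: a 1.3-fold lower number from compound 3 to compound 4 (0.11 log units; within the scatter). For compound 4 the estimated value in this assay is 25000 nM, with an expected range of 9000 nM to 60000 nM.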

Compound 4, concentration for 50% growth inhibition: 27000 nM
Estimate against measurement, compound 4: 1.1-fold (0.03 log units) below, and the stated range covers the measured number.
By their numbers in this assay, from the lowest: compound 1; then compounds 4, 2 and 3 (each within the scatter of the next).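

Benzyl on an oxygen next to a carbonyl group brings the first aromatic ring to this position, and it gives a 1.2-fold lower number from compound 3 to compound 4 (0.07 log units; within the scatter) and a 1.1-fold lower number from compound 2 to compound 4 (0.05 log units; within the scatter), so neither step separates it from the tert-butyl or ethyl esters. Compound 1 remains apart from the benzyl ester, with a 3.9-fold higher number from compound 1 to compound 4 (0.59 log units; beyond the scatter), which leaves the methyl ester alone at the low-number end while compound 2, compound 3 and compound 4 sit together within the scatter, despite the difference between the open chain, branched and aromatic groups. Nothing in hand accounts for this shared level or for the separate place of the methyl ester.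

From the compounds shown here alone, whether a free carboxylic acid or a primary amide at this position would fall with compound 1 or beyond it remains open. So does whether a longer chain ending in phenyl, or a benzyl ring bearing a methoxy group, would stay with compound 4.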